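The source may report more compounds than this note shows. Statements on the series, on what has been measured and on what is new or still open speak of the compounds shown alone.

Among the measured compounds shown here, in a functional assay on KB cells (Homo sapiens) for antiproliferative activity, read by MTT assay, with a stated time of 48 h (on this read-out lower numbers stand for stronger inhibition and higher numbers for weaker inhibition), compound 1 `Cn1cc(C2=C(c3nn(CCCN4CCCCC4)c4ncccc34)C(=O)N(c3cccc4ccccc34)C2=O)c2ccccc21` gives 13400 nM, the lowest number among the compounds measured so far. Compound 3 `Cn1cc(C2=C(c3nn(CCCN4CCCCC4)c4ncccc34)C(=O)NC2=O)c2ccccc21`, with hydrogen in place of naphthalen-1-yl on an amide-type nitrogen in a ring, gives 98000 nM. That change is a 7.3-fold higher number from compound 1 to compound 3 (0.86 log units; beyond the scatter). Compound 2 `Cn1cc(C2=C(c3nn(CCCN4CCCCC4)c4ncccc34)C(=O)N(c3ccccn3)C2=O)c2ccccc21`, with pyridin-2-yl at that nitrogen, gives > 100000 nM, which is a limit of the assay. That change is an at least 7.4-fold higher number from compound 1 to compound 2 (0.87 log units; beyond the scatter).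

Compound 4 `Cn1cc(C2=C(c3n[nH]c4ncccc34)C(=O)N(c3cccc4ccccc34)C2=O)c2ccccc21` differs from compound 1 at another place, with hydrogen in place of 3-(piperidin-1-yl)propyl on an aromatic nitrogen. For the measured compounds named here, no measured step touches this place, so the two steps at the amide-type nitrogen serve only as a rough guide to size. A clear direction cannot be drawn from them, and a shift of about their size in either direction remains possible.

The expected change is small, and the estimate is a 1.3-fold higher number from compound 1 to compound 4 (0.13 log units; within the scatter). In this assay, compound 4 is expected to give 18000 nM, with an estimated range of 4000 nM to 80000 nM.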

Compound 4, half-maximal inhibitory concentration: > 100000 nM
Compound 4: no number, only a limit (the forecaster's own chance of this, stated with the estimate: 20%); middle value at least 5.5-fold (0.74 log units) away from the limit.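

Among the compounds shown here, on the aromatic nitrogen, hydrogen in place of 3-(piperidin-1-yl)propyl gives an at least 7.4-fold higher number from compound 1 to compound 4 (0.87 log units; beyond the scatter) in this assay and so shows that this position, untouched by the earlier steps, also bears on the read-out. Compound 4 keeps the naphthalen-1-yl group of compound 1, so that group alone does not bring the compound to a measurable number. The result for compound 4 is a limit of the assay, which makes the step a floor whose full size cannot be read: the limit of > 100000 nM in this assay, at which 2 of the 4 values shown sit.

The compounds shown leave open whether the piperidine ring or the propyl chain matters more, a question that an ethyl chain ending in the same ring, or a propyl chain ending in morpholine or dimethylamine, could address. They also leave open whether a simple methyl group on that nitrogen would differ from hydrogen.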